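This account rests on a few compounds, and the source may have more. Where it says the series, first, only, none or still open, it means among the compounds named here.

Of the compounds shown here, three built on a shared core have been tested in a toxicity assay on MT2 cells (Homo sapiens) for cytotoxicity, read by MTT assay; a lower number here means that less compound is tolerated, a higher number that more compound is tolerated. Compound 1, `N#Cc1ccc2ccc(Oc3ccccc3OCCn3ccc(=O)[nH]c3=O)cc2c1`, gives 15000 nM. Compound 2, `Cc1c(Oc2ccccc2OCCn2ccc(=O)[nH]c2=O)cc(F)c2ccc(C#N)cc12`, reaches only the assay limit of > 100000 nM, so no number is known for it. Compound 3, `Cc1c(Oc2ccccc2OCCn2ccc(=O)[nH]c2=O)cc(Cl)c2ccc(C#N)cc12`, likewise sits at the limit of > 100000 nM. The step that the two limits leave unreadable from compound 2 to compound 3 is therefore not readable, and the limit of > 100000 nM in this assay, at which 2 of the 3 values shown sit, is all that these two limits show. Compound 4, `CCOc1cc(Oc2ccccc2OCCn2ccc(=O)[nH]c2=O)c(C)c2cc(C#N)ccc12`, differs from compound 2 by ethoxy in place of fluoro on an aromatic carbon. Among the compounds with values here, no measured step covers this change, so only the limit of compound 2 can guide the expectation. Compound 4 is expected to give 80000 nM, within 30000 nM to 200000 nM. The expected step of an at least 1.2-fold lower number from compound 2 to compound 4 (0.09 log units; that floor lies within the scatter) is an estimate, not a measurement.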

Compound 4, half-maximal cytotoxic concentration: > 100000 nM
Compound 4 gave a limit, no number; the forecaster's own chance of this, stated with the estimate: 55%; middle value at least 1.2-fold (0.09 log units) from the limit.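

Compound 4 also gives a limit, not a number: > 100000 nM. Steps from compound 2 and compound 3 to compound 4 therefore cannot be read: the limit of > 100000 nM in this assay, at which 3 of the 4 values shown sit.

On these data alone, whether fluoro, chloro or ethoxy changes the tolerated concentration in this assay remains open.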